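A few compounds are considered here, and "the series" means these few. Any claim that something is new, unique, unknown or untested is made for them only; others in the source may bear on it.

Compound 1 `O=C(O)C(CSCCn1c(-c2ccccc2)n[nH]c1=S)c1ccccc1`: > 250000 nM
Compound 2 `S=c1[nH]nc(-c2ccccc2)n1CCSCc1ccccc1`: 152000 nM

Both compounds were tested in a functional assay on HeLa cells (Homo sapiens) for cytotoxicity, read by LDH release, with a stated time of 24 h; on this read-out lower numbers stand for stronger inhibition and higher numbers for weaker inhibition. Compound 1 gives > 250000 nM, which is a limit of the assay and not a number. Going by the values given here, compound 2 gives 152000 nM, the only true number in this small set, and so it is the one firm reference point for what follows.

The next compound, compound 3 `Fc1ccccc1CSCCn1c(-c2ccccc2)n[nH]c1=S`, keeps the whole of compound 2 except for one change, from phenyl to 2-fluorophenyl: fluoro in place of hydrogen on an aromatic carbon. This places fluoro in place of hydrogen on an aromatic carbon, ortho to a large group. Among the compounds with values here, no measured pair differs in one place only, so the data do not show how a change of this kind behaves in this assay.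

With so small a swap, no step beyond the usual scatter is expected, in either direction, from the starting point of compound 2 at 152000 nM. The expected step is a 1.2-fold lower number from compound 2 to compound 3 (0.07 log units; within the scatter). For compound 3 the estimated value is 130000 nM, with an expected range from 60000 nM to 250000 nM.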

Compound 3, half-maximal inhibitory concentration: 165000 nM
The estimate for compound 3 lay 1.3-fold (0.10 log units) below the measured number; low and high end bracket the measured number.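

In this assay, fluoro in place of hydrogen on an aromatic carbon gives a 1.1-fold higher number from compound 2 to compound 3 (0.04 log units; within the scatter), so this swap leaves the two compounds indistinguishable on this read-out. Going by these compounds alone, this is the first single change that can be read at all, since the earlier compounds offered no pair differing in one place only: at this place, ortho to a large group on the ring, fluoro in place of hydrogen produces no step beyond the usual scatter. Compound 1 still offers no number to set beside this result, as its value is a limit of the assay: the limit of > 250000 nM in this assay, at which 1 of the 3 values shown sits.

The compounds shown leave open whether a different group at the same place, such as chlorine, methoxy or an amine, would move the number beyond the scatter, and whether fluoro elsewhere on this ring would behave as it does here. They also say nothing about changes to the phenyl on the shared core or to the chain that links it to the fluorinated ring, such as a longer chain.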